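Removal of an aromatic methoxy from the aminopyrimidine series

The source may hold more compounds than are shown below. What is called first, only, known or untested is meant among the compounds shown, and "the series" means these compounds.

Measured compounds:
- Compound 1 `CCCN(CCC)c1ccc(Nc2ncc(Cl)c(Oc3cccc(NC(=O)CC)c3)n2)cc1` — "not active" (no number reported)
- Compound 2 `CCC(=O)Nc1cccc(Oc2nc(Nc3ccc(N4CCN(C)CC4)cc3)ncc2Cl)c1` — 82.6%
- Compound 3 `CCC(=O)Nc1cccc(Oc2nc(Nc3ccc(N4CCC(OC)CC4)cc3OC)ncc2Cl)c1` — "not active" (no number reported)

In an assay on isolated protein for inhibition of NUAK family SNF1-like kinase 2 (Homo sapiens), read by ADP-Glo, with a stated time of 60 min, tested at 10 uM, in the presence of a further agent that is not named here (a higher number here means more inhibition at the concentration tested (going by the name of the read-out), a lower number less inhibition), compound 2 gives 82.6%. Compound 1 is reported in this assay as "not active" (no number reported), with no number attached. Compound 3 likewise carries no single number in this assay and is reported as "not active" (no number reported); it is one of two entries in the set for which only this wording, and no value, is given.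

Compound 4 `CCC(=O)Nc1cccc(Oc2nc(Nc3ccc(N4CCC(OC)CC4)cc3)ncc2Cl)c1` has not yet been measured. Compared with compound 3 it differs as follows: hydrogen in place of methoxy on an aromatic carbon. Compound 4 shares with compound 2 the absence of any substituent on the ring that carries the amine, while keeping the 4-methoxypiperidin-1-yl group of compound 3. Among the measured compounds shown here, compound 2 is the only measured compound with a reported number, and compound 1 shows that an unsubstituted ring alone does not guarantee a number.

For the measured compounds named here, no step between measured compounds is available. Given that compound 3 has no number, the change to compound 4 is expected to move inhibition upward in this assay, plausibly beyond the scatter, though the degree is uncertain. For compound 4 the estimate is 50%, with a range from 10% to 85%.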

Compound 4, a percentage reported as inhibition, at one concentration (the size of the read-out at that concentration, not a potency): 53.4%
Beside the measured number, compound 4's estimate is 3.4 percentage points below it; measured number inside the range.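

In this assay compound 3 is reported as "not active" (no number reported), whereas compound 4, with hydrogen in place of methoxy on the aromatic carbon ortho to a large group, gives 53.4%; within this pair, a measurable reading appears only with hydrogen at this position. Compound 3 has no number. No size can be assigned to the change. Compound 4 also shows that the 4-methoxypiperidin-1-yl group can carry a reported number, while the change from 4-methylpiperazin-1-yl to 4-methoxypiperidin-1-yl gives a number 29.2 percentage points lower from compound 2 to compound 4 (beyond the scatter). No measurement available here accounts for either difference.

On these data alone, it remains open whether the absence of a number is specific to methoxy or extends to other groups at this position, such as fluorine or methyl. Also open, as far as these compounds go, is whether methoxy at this position has the same outcome alongside 4-methylpiperazin-1-yl, or alongside another ring such as morpholine.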